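Alkoxy variation on a shared aminoquinoline core

This account rests on a few compounds, and the source may have more. Where it says the series, first, only, none or still open, it means among the compounds named here.

Measured so far:
compound 1 `CCCCCOc1cccc2ccc(N)nc12`, 580 nM
compound 2 `CC(C)Oc1cccc2ccc(N)nc12`, 437 nM

In an assay on cells with melanin-concentrating hormone receptor 1 (Homo sapiens) as the target, read by radioligand binding (on this read-out higher numbers stand for weaker inhibition and lower numbers for stronger inhibition), compound 2 gives the lowest of the two numbers, yet the step of a 1.3-fold lower number from compound 1 to compound 2 (0.12 log units; within the scatter) lies within the scatter, so compound 1 and compound 2 cannot be separated. Compound 3 `Nc1ccc2cccc(OC3CCCC3)c2n1` differs from compound 2 by cyclopentyl in place of isopropyl on an oxygen on an aromatic ring. For the measured compounds named here, the only measured step bearing on this position, a 1.3-fold lower number from compound 1 to compound 2 (0.12 log units; within the scatter), was within the scatter, so no step beyond the scatter is expected in this assay from this change either. Compound 3 is therefore estimated at 350 nM (range 120 nM to 1000 nM), a step of a 1.2-fold lower number from compound 2 to compound 3 (0.10 log units; within the scatter).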

Compound 3, half-maximal inhibitory concentration: > 2000 nM
Compound 3: a limit, no number; the forecaster's own chance of this, stated with the estimate: 3%; middle value at least 5.7-fold (0.75 log units) away from the limit.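

With cyclopentyl on this oxygen, the position proves sensitive to its group: the change gives an at least 4.5-fold higher number from compound 2 to compound 3 (0.66 log units; beyond the scatter), and replacing pentyl gives an at least 3.4-fold higher number from compound 1 to compound 3 (0.53 log units; beyond the scatter). In this assay, for the compounds shown here, pentyl and isopropyl could not be separated, so these are the first steps at this position beyond the scatter. The result for compound 3 is a limit of the assay, not a number, so both steps have no upper size: the limit of > 2000 nM in this assay, at which 1 of the 3 values shown sits.

From the compounds shown here alone, it remains open whether this holds for rings generally or for cyclopentyl alone. A cyclopropyl group or a chain ending in an amine on the same oxygen would bear on this.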